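A halogenated aryl replaces phenyl on the core nitrogen

A few compounds are considered here, and "the series" means these few. Any claim that something is new, unique, unknown or untested is made for them only; others in the source may bear on it.

Among the measured compounds shown here, compound 3 `O=C(Nc1ccc(Oc2ccnc3[nH]ccc23)c(F)c1)c1cc2cccnc2n(-c2ccccc2)c1=O` stands as the strongest of the three compounds measured so far: in a functional assay on A549 cells (Homo sapiens) for antiproliferative activity, read by MTT assay, with a stated time of 72 h (a higher number here means a weaker inhibitor, a lower number a stronger inhibitor), compound 3 gives 190 nM. Compound 1 `O=C(Nc1ccc(Oc2ccnc3[nH]ccc23)cc1)c1cc2cccnc2n(-c2ccc(F)c(Cl)c2)c1=O` gives 680 nM in this assay, and compound 2 `O=C(Nc1ccc(Oc2ccnc3[nH]ccc23)cc1)c1cc2cccnc2n(-c2ccc(C(F)(F)F)cc2Cl)c1=O` gives 3230 nM. Compound 4 `O=C(Nc1ccc(Oc2ccnc3[nH]ccc23)c(F)c1)c1cc2cccnc2n(-c2ccc(Br)cc2F)c1=O` has not yet been measured; it differs from compound 3 in one place: 4-bromo-2-fluorophenyl in place of phenyl on an aromatic nitrogen.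

For the measured compounds named here, only one measured step changes the aryl at this same position. There, a 4.8-fold higher number from compound 1 to compound 2 (0.68 log units; beyond the scatter), so exchanging one halogenated aryl for another bearing chloro and trifluoromethyl weakened activity modestly. Going by the values given here, compound 1 and compound 3 differ in two places, so their two values show only that compound 3, which carries the plain phenyl, gives the lower number. Among the compounds with values here, nothing measured tells directly what bromo and fluoro together do on this ring; the one comparable step went in the weakening direction, and the plain phenyl compound holds the lowest number, so a modest rise in the number in this assay is expected rather than a gain.

For compound 4 the expected step is a 2.4-fold higher number from compound 3 to compound 4 (0.37 log units; beyond the scatter), a modest weakening. Compound 4 is therefore estimated to give about 450 nM in this assay, with a range from 150 nM to 1500 nM.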

Compound 4, half-maximal inhibitory concentration: 460 nM
Beside the measured number, compound 4's estimate is 1.0-fold (0.01 log units) below it, and the stated range covers the measured number.
By their numbers in this assay, from the lowest: compound 3; then compounds 4 and 1 (each within the scatter of the next); then compound 2.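

Among the compounds shown here, this is the first step at this position that starts from a plain phenyl ring: putting 4-bromo-2-fluorophenyl in its place on the aromatic nitrogen gives, in this assay, a 2.4-fold higher number from compound 3 to compound 4 (0.38 log units; beyond the scatter). Within this one pair, the two halogens cost some activity without removing it, and the number stays well short of the weakest value seen so far. For the compounds shown here, the only other step at this position, where one halogenated aryl replaces another on a core without the extra fluorine, also goes upward, with a 4.8-fold higher number from compound 1 to compound 2 (0.68 log units; beyond the scatter), so both steps at this position so far weaken activity, although they start from different aryl groups, and nothing available explains the rise in either case.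

From the compounds shown here alone, it remains open whether the bromine, the fluorine or only the two together account for the rise from the plain phenyl compound. Also open, going by these compounds, is how this position responds to a different kind of group on the ring, such as an amine, a carboxylic acid or a methoxy group, or to a longer chain in place of the aryl ring.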